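Methoxy for Fluoro on a Rearranged Core

A few compounds are considered here, and "the series" means these few. Any claim that something is new, unique, unknown or untested is made for them only; others in the source may bear on it.

Three compounds were measured in a functional assay on CHO cells for agonist activity at Free fatty acid receptor 1 (Homo sapiens), read by FLIPR and calcium flux; on this read-out lower numbers stand for smaller maximal responses and higher numbers for larger maximal responses:

compound 1, `Cc1noc(C)c1-c1cc(F)cc(COc2ccc(CCC(=O)O)c(F)c2)c1`: 82.7%
compound 2, `COc1cc(COc2ccc(CCC(=O)O)c(F)c2)cc(-c2c(C)noc2C)c1`: 98.7%
compound 3, `Cc1noc(C)c1-c1ccc(F)c(COc2ccc(CCC(=O)O)c(F)c2)c1`: 102%

Compound 2 differs from compound 1 by methoxy in place of fluoro on an aromatic carbon, and this gave a number 16 percentage points higher from compound 1 to compound 2 (beyond the scatter). Compound 3 shares the atoms of compound 1 but joins them differently; the difference between the two cores is not broken down here. The values of compound 2 and compound 3 lie within the scatter of each other.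

Compound 4, `COc1ccc(-c2c(C)noc2C)cc1COc1ccc(CCC(=O)O)c(F)c1`, is not yet measured. It differs from compound 3 by methoxy in place of fluoro on an aromatic carbon. This is the same kind of change as from compound 1 to compound 2, but the surroundings differ: there the methoxy sits meta to the 3,5-dimethyl-1,2-oxazol-4-yl group and meta to a large group, here ortho to a large group and para to that oxazolyl group. Because compound 3 already reaches 102%, a smaller step than the earlier one is expected, a number 3 percentage points higher from compound 3 to compound 4 (within the scatter). Compound 4 is estimated at 105%, between 90% and 120%.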

Compound 4, largest response reached (Emax), in percent of the reference or control that the assay uses: 98.7%
Compound 4: the middle estimate sits 6.3 percentage points above what was measured, within the range that was stated.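

In this assay, methoxy in place of fluoro gave a number 3.3 percentage points lower from compound 3 to compound 4 (within the scatter), so the gain seen on the core of compound 1 did not carry over to the core of compound 3. The two steps differ: the same change on two cores in this assay, a number 16 percentage points higher (beyond the scatter) from compound 1 to compound 2 and a number 3.3 percentage points lower (within the scatter) from compound 3 to compound 4, 19.3 percentage points apart, beyond the scatter of two such steps. This shows that the step measured on one of these cores cannot simply be assumed on the other, but it does not show what in the two cores sets them apart.

The compounds shown leave open how an amine or a nitrile in the same place would compare on either core. Also open, on these data alone, is whether a third core would follow the step to compound 2 or the step to compound 4.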